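Expected Gain From a Larger Sulfonyl Group

This account rests on a few compounds, and the source may have more. Where it says the series, first, only, none or still open, it means among the compounds named here.

Three related compounds have been measured in a functional assay on HCC1806 cells (Homo sapiens) for inhibition, read by sulforhodamine B assay, tested at 10 uM; on this read-out lower numbers stand for less inhibition and higher numbers for more inhibition at the one concentration tested (going by the name of the read-out). Compound 1 `CN1CCN(c2ccc(C3=NN(S(C)(=O)=O)C(c4ccc(N(C)C)cc4)C3)cc2)CC1` gives -18.5% in this assay. Compound 2 `Cc1ccc(S(=O)(=O)N2N=C(c3ccc(N4CCN(C)CC4)cc3)CC2c2ccc(N(C)C)cc2)cc1` differs from compound 1 by 4-methylphenyl in place of methyl on a sulfonyl sulfur, and compound 2 gives 32.2%; the change made a large step, a number 50.7 percentage points higher from compound 1 to compound 2 (beyond the scatter). Compound 3 `CN(C)c1ccc(C2CC(c3ccc(-n4ccnc4)cc3)=NN2S(C)(=O)=O)cc1` differs from compound 1 by 1H-imidazol-1-yl in place of 4-methylpiperazin-1-yl on an aromatic carbon, and compound 3 gives 11.3%, a modest step, a number 29.8 percentage points higher from compound 1 to compound 3 (beyond the scatter).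

Compound 4 `Cc1ccc(S(=O)(=O)N2N=C(c3ccc(-n4ccnc4)cc3)CC2c2ccc(N(C)C)cc2)cc1` has not yet been measured. It differs from compound 3 by 4-methylphenyl in place of methyl on a sulfonyl sulfur. The place of this change is described in the same words as for the change from compound 1 to compound 2, so it is the same change, applied on a different core; the two cores differ as described by 1H-imidazol-1-yl in place of 4-methylpiperazin-1-yl on an aromatic carbon.

For compound 4 a step of about a number 43.7 percentage points higher from compound 3 to compound 4 (beyond the scatter) is expected, somewhat smaller than the earlier one because a number 50.7 percentage points higher from compound 1 to compound 2 (beyond the scatter) was measured on a core that is not the same. Compound 4 is therefore estimated at 55%, between 30% and 78%.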

Compound 4, a percentage reported as inhibition, at one concentration (the size of the read-out at that concentration, not a potency): 66%
Beside the measured number, compound 4's estimate is 11 percentage points below it; the range from low to high includes it.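

In this assay, putting 4-methylphenyl in place of methyl on the sulfonyl sulfur gives a number 54.7 percentage points higher from compound 3 to compound 4 (beyond the scatter), and this change carries over from the core of compound 1 to the core of compound 3 with much the same size: the same change on two cores in this assay, a number 50.7 percentage points higher (beyond the scatter) from compound 1 to compound 2 and a number 54.7 percentage points higher (beyond the scatter) from compound 3 to compound 4, 4 percentage points apart, within the scatter of two such steps. The other change, 1H-imidazol-1-yl in place of 4-methylpiperazin-1-yl, gives a number 33.8 percentage points higher from compound 2 to compound 4 (beyond the scatter), and it also holds up when the sulfonyl group differs: the same change on two cores in this assay, a number 29.8 percentage points higher (beyond the scatter) from compound 1 to compound 3 and a number 33.8 percentage points higher (beyond the scatter) from compound 2 to compound 4, 4 percentage points apart, within the scatter of two such steps. Within these four compounds the two changes therefore behave as if independent of each other, but this rests on just two cores, one cell line and a single concentration, so it does not show that the same steps would appear on other cores or that potency changes in the same way.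

The compounds shown leave open whether another group on the sulfonyl sulfur, such as an unsubstituted phenyl or a longer chain like n-butyl, would give a similar step. They also leave open how a morpholine in place of 1H-imidazol-1-yl would behave.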